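This account rests on a few compounds, and the source may have more. Where it says the series, first, only, none or still open, it means among the compounds named here.

The measured compounds and their values:

compound 1, `N=C(NCCCc1c[nH]cn1)NCCCC(c1ccccc1)c1ccccn1`: 1
compound 2, `N=C(NCCCc1c[nH]cn1)NCCC(c1ccc(Cl)cc1)c1ccccn1`: 1
compound 3, `N=C(NCCCc1c[nH]cn1)NCCC(c1ccccn1)c1ccccc1F`: 1

All three were tested in a functional assay on cardiac atrium for agonist activity at histamine H2 receptor (Cavia porcellus); a lower number here means a smaller maximal response, a higher number a larger maximal response. Compound 2 stands level with compound 1 and compound 3 at the digits shown, and the one step in this set that alters a single place, no change at the digits printed from compound 2 to compound 3 (within the scatter), lies within the scatter. Compound 1 carries a different chain length and is not joined to compound 2 by a single-place step, so only its value is compared, and it too matches.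

The next compound, compound 4, `N=C(NCCCc1c[nH]cn1)NCCC(c1ccccn1)c1ccccn1`, differs from compound 2 in one place: pyridin-2-yl in place of 4-chlorophenyl on a saturated chain carbon bound to an aromatic carbon and a saturated chain carbon. Within the data shown here, the step that bears on it is the one from compound 2 to compound 3, which changed the group at the same place and gave no shift beyond the scatter. On that basis a full response is expected again, with no step beyond the scatter. This expectation amounts to no change at the digits printed from compound 2 to compound 4 (within the scatter). Compound 4 is therefore estimated to give 1 in this assay, between 0.9 and 1.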

Compound 4, intrinsic activity: the largest response reached, as a fraction of the reference agonist's: 1
Beside the measured number, compound 4's estimate shows no gap at the digits printed; the range from low to high includes it.
By their numbers in this assay, from the lowest: compounds 1, 2, 3 and 4 (each within the scatter of the next).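

In this assay, the place on a saturated chain carbon bound to an aromatic carbon and a saturated chain carbon now proves to tolerate a ring with a hetero atom, where compounds 2 and 3 held rings of carbon only: the step is no change at the digits printed from compound 2 to compound 4 (within the scatter). The comparison with the fluorinated ring reads the same, no change at the digits printed from compound 3 to compound 4 (within the scatter), so pyridin-2-yl, which brings a hydrogen-bond acceptor that neither 4-chlorophenyl nor 2-fluorophenyl has, leaves the maximal response in place. Nothing at hand explains why the response holds across these changes.

With all these values level, the read-out does not separate the groups tested at this place. From the compounds shown here alone, whether a cyclohexyl ring, an amine or a carboxylic acid there would keep the same maximal response remains open.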